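Fluorophenyl Piperazine Sulfonamide Analogue Awaits Binding Measurement

This account rests on a few compounds, and the source may have more. Where it says the series, first, only, none or still open, it means among the compounds named here.

Two analogues sharing one core have been measured in an assay on CHO cells for displacement of a labelled ligand from adenosine receptor A1 (Homo sapiens), read by scintillation counting, with a stated time of 90 min, in the presence of a further agent that is not named here; on this read-out lower numbers stand for stronger inhibition and higher numbers for weaker inhibition. Compound 1 `CCCn1c(=O)[nH]c2nc(-c3ccc(S(=O)(=O)N(C)C)cc3)[nH]c2c1=O` gives 190 nM, while compound 2 `CCCn1c(=O)[nH]c2nc(-c3ccc(S(=O)(=O)N4CCN(C)CC4)cc3)[nH]c2c1=O` gives 334 nM. Compound 2 holds the higher of the two numbers, but the step of a 1.8-fold higher number from compound 1 to compound 2 (0.24 log units; within the scatter) lies within the scatter. That step, 4-methylpiperazin-1-yl in place of dimethylamino on the sulfonyl sulfur, is the only one measured, and it bears on compound 3 `CCCn1c(=O)[nH]c2nc(-c3ccc(S(=O)(=O)N4CCN(c5ccccc5F)CC4)cc3)[nH]c2c1=O` only loosely. Within the data shown here, compound 3 differs from compound 2 by 2-fluorophenyl in place of methyl on an amine nitrogen in a ring, an exchange no measured pair makes. With nothing directly comparable, the likely outcome is a modest drift upward in the number, not clearly beyond the scatter, with a wide range to reflect the uncertainty. Compound 3 is therefore expected to give about 500 nM, within roughly 150 nM to 1700 nM. For compound 3 this amounts to an expected step of a 1.5-fold higher number from compound 2 to compound 3 (0.18 log units; within the scatter).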

Compound 3, inhibition constant: > 1000 nM
Compound 3 ended at the assay's limit; the forecaster's own chance of this, stated with the estimate: 5%; middle value at least 2.0-fold (0.30 log units) away from the limit.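

Among these compounds, the exchange of methyl for 2-fluorophenyl on the amine nitrogen in the ring gives an at least 2.9-fold higher number from compound 2 to compound 3 (0.47 log units; beyond the scatter) and is the only step here beyond the scatter. The earlier exchange on the sulfonyl sulfur gave a 1.8-fold higher number from compound 1 to compound 2 (0.24 log units; within the scatter) and so showed no clear effect, whereas this position, three ring bonds from the ring nitrogen, clearly responds to the group it carries, with weaker inhibition for the larger aromatic group. In this assay compound 3 gives > 1000 nM, which is a limit of the assay and not a number: the limit of > 1000 nM in this assay, at which 1 of the 3 values shown sits.

The compounds shown leave open how large the step truly is and whether it follows from the phenyl ring itself or from its fluorine. An unsubstituted phenyl, a benzyl group or an ethyl chain on the same nitrogen would bear on that question.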